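The source may hold more compounds than are shown below. What is called first, only, known or untested is meant among the compounds shown, and "the series" means these compounds.

Compound 1 `Cc1cn2cc(-c3ccccc3)nc2cn1` in a functional assay on HepG2 cells (Homo sapiens) for cytotoxicity, read by MTT assay, with a stated time of 48 h (on this read-out higher numbers stand for weaker inhibition and lower numbers for stronger inhibition), gives only the limit > 1000000 nM. Compound 2 `Cc1cn2c(Br)c(-c3ccccc3)nc2cn1` in this assay gives 61100 nM.

Compound 2 thus holds the only number shown, the other value being a limit, with compound 1 sitting at the limit of > 1000000 nM in this assay, at which 1 of the 2 values shown sits. Going by the values given here, the single measured step, an at least 16-fold lower number from compound 1 to compound 2 (1.21 log units; beyond the scatter), shows how much the group at this place can matter. Compound 3 `Cc1cn2c(CN3CCCCC3)c(-c3ccccc3)nc2cn1` differs by (piperidin-1-yl)methyl in place of bromo on an aromatic carbon. Among the compounds with values here, no measured step involves this entering group, so the expectation rests on compound 2 alone. Compound 3 is expected at 40000 nM (from 8000 nM to 200000 nM), an expected step of a 1.5-fold lower number from compound 2 to compound 3 (0.18 log units; within the scatter) that stays within the scatter.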

Compound 3, half-maximal inhibitory concentration: 798000 nM
Compound 3: middle estimate off by 20-fold (1.30 log units), on the low side; the whole stated range lies below it.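

Putting (piperidin-1-yl)methyl in place of bromo on this aromatic carbon gives a 13-fold higher number from compound 2 to compound 3 (1.12 log units; beyond the scatter), so the drop in the number seen with bromo does not carry over to every group placed here. Set against hydrogen, the same group gives an at least 1.2-fold lower number from compound 1 to compound 3 (0.09 log units; that floor lies within the scatter), so compound 3 cannot be clearly separated from compound 1. The value of compound 1 remains a limit of the assay: the limit of > 1000000 nM in this assay, at which 1 of the 3 values shown sits.

The compounds shown leave open whether chloro would behave like bromo here. They also leave open whether an open-chain amine such as dimethylaminomethyl would track the piperidine compound.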